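A Ring Swap on the Amide Nitrogen and Solubility

The source may report more compounds than this note shows. Statements on the series, on what has been measured and on what is new or still open speak of the compounds shown alone.

compound 1 `COc1ccc2nc(C)cc(NCC(=O)Nc3cc(C)cc(C)c3)c2c1`: 204000 nM
compound 2 `COc1ccc2nc(C)cc(OCC(=O)Nc3ccccc3)c2c1`: 63000 nM
compound 3 `COc1ccc2nc(C)cc(OCC(=O)Nc3ccc(Cl)c(C(F)(F)F)c3)c2c1`: 17000 nM

Of the compounds shown here, three sharing one core have been measured in a physicochemical assay for solubility, in phosphate buffer, measured as kinetic solubility, with a stated time of 1 h, at pH 7.4; a higher number here means a more soluble compound, a lower number a less soluble compound. Compound 2 stands second highest of the three numbers. Its nearest neighbour is compound 1, which gives a higher number, and the furthest is compound 3, which gives a lower one; both gaps lie beyond the usual scatter of this assay. For the measured compounds named here, no pair among the measured compounds differs in a single place, so no step can be read directly from them.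

Compound 4 `COc1ccc2nc(C)cc(OCC(=O)NC3CONC3=O)c2c1` has not yet been measured in this assay. It is derived from compound 2 by the following change: a group of 6 heavy atoms (3 carbon, 1 nitrogen, 2 oxygen; one five-membered non-aromatic ring with 2 hetero atoms) in place of a group of 6 heavy atoms (6 carbon; one six-membered aromatic ring of carbon only), on an amide-type nitrogen. A six-membered aromatic ring of carbon only leaves, and a five-membered non-aromatic ring with two hetero atoms, one hydrogen-bond donor and two hydrogen-bond acceptors enters on the amide-type nitrogen. Going by the values given here, no measured step speaks to this kind of exchange, so the expectation rests on the counted difference alone. Compound 4 is expected to show a step upward, beyond the scatter, of a 4.0-fold higher number from compound 2 to compound 4 (0.60 log units; beyond the scatter). Compound 4 is therefore estimated at 250000 nM, within a range from 90000 nM to 700000 nM.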

Compound 4, solubility: >= 166000 nM
Compound 4 gave a limit, no number (the forecaster's own chance of this, stated with the estimate: 10%); the middle value lies beyond the limit too.
By their numbers in this assay, from the lowest: compound 3; then compound 2; then compound 1.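

The exchange on the amide-type nitrogen gives the only single-place step among these compounds, and in this assay it amounts to an at least 2.6-fold higher number from compound 2 to compound 4 (0.42 log units; beyond the scatter). The earlier compounds shown here differed in more than one place and could only be ranked, whereas this step ties a rise in the read-out to one exchange: phenyl leaves, and a five-membered non-aromatic ring with 2 hetero atoms enters. Compound 4 gave a limit of the assay and not a number, so the step has a floor but no known upper end, and its full size cannot be read: the limit of >= 166000 nM in this assay, at which 1 of the 4 values shown sits.

The compounds shown leave open whether the rise goes with the loss of phenyl itself or with the hetero atoms, the double bond outside aromatic rings and the hydrogen-bond donor and acceptors of the entering ring; a cyclopentyl group on the same nitrogen would separate these. They also leave open how an amine or a carboxylic acid on that ring, or a longer chain in its place, would read in this assay.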